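The compounds below may be only part of what the source reports. "The series", "measured", "known", "first", "only" and "open" are said of these compounds alone.

Measured compounds:
compound 1, `Nc1nc(O)c2c(n1)n(C1OC(CO)[C@@H](O)[C@H]1O)c(=O)n2CC(O)CO`: 45 uM
compound 2, `C=CCn1c(=O)n(CCCC)c2nc(N)nc(O)c21`: 2 uM

Both were tested in a functional assay (B cells) with Mus musculus as the target; a lower number here means that less compound is needed, a higher number that more compound is needed for the effect. Compound 1 gives the higher of the two numbers there, and compound 2 gives a number that lies beyond the usual scatter lower, so compound 2 needs less compound for the same effect. Within the data shown here, no pair differing in a single place has been measured, so nothing observed yet tells how one change shifts the read-out.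

Compound 3, `Cn1c(=O)n(C2OC(CO)[C@@H](O)[C@H]2O)c2nc(N)nc(O)c21`, is not yet measured in this assay. It differs from compound 1 by hydrogen in place of 1,2-dihydroxyethyl on a saturated chain carbon bound to an aromatic nitrogen; the rest of compound 1 stays. Compound 2 is not a single-change neighbour of compound 1, so it gives no direct guide to this change. The step is expected to be small, within the usual scatter in either direction: a 1.5-fold lower number from compound 1 to compound 3 (0.18 log units; within the scatter). Compound 3 is therefore expected to give about 30 uM, in the range 8 uM to 120 uM.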

Compound 3, concentration for half-maximal effect: 10 uM
Beside the measured number, compound 3's estimate is 3.0-fold (0.48 log units) above it, within the range that was stated.
By their numbers in this assay, from the lowest: compound 2; then compound 3; then compound 1.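

In this assay, among these compounds, the change of 2,3-dihydroxypropyl to methyl gives a 4.5-fold lower number from compound 1 to compound 3 (0.65 log units; beyond the scatter) and is the first single change that can be read. This shows that the position, a saturated chain carbon bound to an aromatic nitrogen, is not indifferent to what it carries: with the core of compound 1 otherwise unchanged, the smaller group needs less compound for the same effect. Nothing at hand explains this shift.

The step removes the chain length and both hydroxyl groups together, so it leaves open which of these matters. A plain propyl chain would test the chain without its hydroxyl groups, while an amine or a carboxylic acid at the end of the chain would show how other groups fare at this position.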